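Methyl to chloro on the aryl of the acrylamide series

The source may report more compounds than this note shows. Statements on the series, on what has been measured and on what is new or still open speak of the compounds shown alone.

Measured so far, in a functional assay on DU-145 cells (Homo sapiens) for inhibition, read by MTT assay, with a stated time of 72 h; on this read-out lower numbers stand for stronger inhibition of growth and higher numbers for weaker inhibition of growth:
compound 1 `COc1ccc(CNC(=O)/C(C#N)=C/c2ccc(C)o2)cc1`, 39000 nM
compound 2 `COc1ccc(CNC(=O)/C(C#N)=C/c2ccc(Cl)o2)cc1`, 12000 nM
compound 3 `COc1ccc(CNC(=O)/C(C#N)=C/c2ccc(C)cc2)cc1`, 34000 nM

Compound 1 and compound 3 share the amide and nitrile part of the core and differ only at the aryl end; the difference is 4-methylphenyl in place of 5-methylfuran-2-yl on a double-bonded chain carbon bound to a double-bonded chain carbon. That exchange gives a 1.1-fold lower number from compound 1 to compound 3 (0.06 log units; within the scatter), so the two cores sit within the scatter of each other and neither can be ordered against the other.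

Within the furan core, one change has been measured: chloro in place of methyl on an aromatic carbon. It gives a 3.3-fold lower number from compound 1 to compound 2 (0.51 log units; beyond the scatter), a modest step that is nonetheless beyond the scatter. Compound 2 against compound 3 shows a 2.8-fold higher number from compound 2 to compound 3 (0.45 log units; beyond the scatter).

Compound 4 `COc1ccc(CNC(=O)/C(C#N)=C/c2ccc(Cl)cc2)cc1` is not yet measured in this assay. It differs from compound 3 by chloro in place of methyl on an aromatic carbon. This is the same kind of change as that from compound 1 to compound 2, not the same: there the place is on a five-membered aromatic ring with 1 oxygen, next to the ring oxygen, two ring bonds from the ring atom that bears a large group; here it is on a six-membered aromatic ring of carbon only, para to a large group.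

Taking compound 3 as the starting point, the step from compound 3 to compound 4 is expected to be about a 3.1-fold lower number from compound 3 to compound 4 (0.49 log units; beyond the scatter), resting on the single measured precedent, the step of a 3.3-fold lower number from compound 1 to compound 2 (0.51 log units; beyond the scatter), and on the cores of compound 1 and compound 3 standing within the scatter of each other. The ring type differs, so the estimate is given a wide range. Compound 4 is expected to give about 11000 nM in this assay, between 5000 nM and 28000 nM.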

Compound 4, concentration for 50% growth inhibition: 7000 nM
Estimate against measurement, compound 4: 1.6-fold (0.20 log units) above; the range from low to high includes it.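

In this assay, chloro in place of methyl on the six-membered aromatic ring of carbon only gives a 4.9-fold lower number from compound 3 to compound 4 (0.69 log units; beyond the scatter), so the change runs the same way on both cores and the two steps cannot be told apart: the same change on two cores in this assay, a 3.3-fold lower number (0.51 log units; beyond the scatter) from compound 1 to compound 2 and a 4.9-fold lower number (0.69 log units; beyond the scatter) from compound 3 to compound 4, 1.5-fold (0.17 log units) apart, within the scatter of two such steps

With chloro on both cores, the aryl exchange gives a 1.7-fold lower number from compound 2 to compound 4 (0.23 log units; within the scatter), so the two cores still cannot be ordered, while the two changes taken together give a 5.6-fold lower number from compound 1 to compound 4 (0.75 log units; beyond the scatter). Among the compounds shown here, this shows that the step carries across the two cores compared here, but it rests on only two matched pairs in a single cell line, so it does not show that the step would carry to any other core, and it gives no reason why chloro and methyl differ.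

On these data alone, whether bromo or trifluoromethyl in the same place would follow chloro stays open. Also open is the amide side of the shared core, which is the same in all the compounds shown, so the effect of an amine or a longer chain there cannot be judged.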